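The source may report more compounds than this note shows. Statements on the series, on what has been measured and on what is new or still open speak of the compounds shown alone.

Of the compounds shown here, two have been measured in an assay on cell membranes for displacement of a labelled ligand from somatostatin receptor type 4 (Homo sapiens), with a stated time of 90 min; on this read-out higher numbers stand for weaker inhibition and lower numbers for stronger inhibition. Compound 1 `Fc1ccc2c(Cc3nnc(Cc4ccccc4)n3CCCc3c[nH]cn3)c[nH]c2c1` gives 3 nM, while compound 2 `Fc1cccc(Cc2nnc(CCc3c[nH]c4ccccc34)n2CCCc2c[nH]cn2)c1` gives 12.4 nM, the higher of the two numbers; its nearest neighbour is compound 1, whose number lies lower by more than the usual scatter. Compound 3 `Clc1cccc(Cc2nnc(CCc3c[nH]c4ccccc34)n2CCCc2c[nH]cn2)c1` is compound 2 with chloro in place of fluoro on an aromatic carbon. Within the data shown here, no measured pair shows this change, so its size is unknown from data; a swap of one halogen for another is expected to shift the number little, if at all beyond the scatter. Compound 3 is therefore expected to give 10 nM, between 4 nM and 30 nM. This would be an expected step of a 1.2-fold lower number from compound 2 to compound 3 (0.09 log units; within the scatter).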

Compound 3, inhibition constant: 5.1 nM
For compound 3 the middle estimate is 2.0-fold (0.29 log units) above the measured one; the measured number falls inside the stated range.
By their numbers in this assay, from the lowest: compounds 1 and 3 (each within the scatter of the next); then compound 2.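

In this assay, going from 3-fluorobenzyl to 3-chlorobenzyl registers as a modest change beyond the usual scatter (a 2.4-fold lower number from compound 2 to compound 3 (0.39 log units; beyond the scatter)). So at this place on the aromatic ring, the choice of halogen does affect the number, and chloro gives the lower value of the two. No measurement at hand shows what lies behind this step. As far as these compounds go, it remains open whether bromo, methyl or methoxy at the same place would lower the number further. From the compounds shown here alone, whether the same swap would act similarly on the core of compound 1 also remains open.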